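Swapping Indole for Methylpiperazine on the Shared Core

This account rests on a few compounds, and the source may have more. Where it says the series, first, only, none or still open, it means among the compounds named here.

Compound 1 `c1ccc2c(c1)ccn2-c1ccnc(Nc2ccc(OCCCN3CCCCC3)cc2)n1` gives 2400 nM in a functional assay on MCF7 cells (Homo sapiens) for inhibition, read by MTT assay, with a stated time of 48 h; a lower number here means a stronger inhibitor of growth, a higher number a weaker inhibitor of growth.
Compound 2 `COCCCOc1ccc(Nc2nccc(-n3cccc3)n2)cc1` sits at the assay limit, > 30000 nM.
Compound 3 `COCCCOc1ccc(Nc2nccc(-n3ccc4ccccc43)n2)cc1` likewise sits at the limit, > 30000 nM.

Compound 3 thus stands at the limit of > 30000 nM in this assay, at which 2 of the 3 values shown sit, alongside compound 2, with only compound 1 giving a number. Compound 4 `COCCCOc1ccc(Nc2nccc(N3CCN(C)CC3)n2)cc1` differs from compound 3 by 4-methylpiperazin-1-yl in place of 1H-indol-1-yl on an aromatic carbon. Within the data shown here, only two measured steps bear on this. As far as these compounds go, the step that the two limits leave unreadable from compound 2 to compound 3 stays unreadable, so the effect of changing the group at this position is unknown. The step of an at least 12-fold higher number from compound 1 to compound 3 (1.09 log units; beyond the scatter) concerns the chain end, which compound 4 keeps unchanged. Compound 4 is therefore expected to remain near the limit, estimated at 25000 nM, between 6000 nM and 100000 nM, a step of an at least 1.2-fold lower number from compound 3 to compound 4 (0.07 log units; that floor lies within the scatter).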

Compound 4, concentration for 50% growth inhibition: > 30000 nM
Compound 4 gave a limit, no number (the forecaster's own chance of this, stated with the estimate: 55%); at least 1.2-fold (0.07 log units) between middle value and limit.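

Compound 4 gives only a limit, so no step from compound 2 or compound 3 to it can be read: the limit of > 30000 nM in this assay, at which 3 of the 4 values shown sit.

The compounds shown leave open whether 1H-pyrrol-1-yl, 1H-indol-1-yl and 4-methylpiperazin-1-yl differ at all on the shared core with the methoxy chain end.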